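From phenyl to 4-fluorophenyl in compound 3

The source may hold more compounds than are shown below. What is called first, only, known or untested is meant among the compounds shown, and "the series" means these compounds.

In an ADME assay on THP-1 cells (Homo sapiens) for cytotoxicity, read by flow cytometry and propidium iodide staining, with a stated time of 72 h (a higher number here means a weaker inhibitor, a lower number a stronger inhibitor), compound 1 (`CC(=O)Nc1ccc2oc(-c3ccccc3F)cc(=O)c2c1`) returned > 125000 nM as a limit of the assay rather than a number. Compound 2 (`CC(=O)Nc1ccc2oc(-c3cccc(C(F)(F)F)c3)cc(=O)c2c1`) gave 50000 nM and compound 3 (`CC(=O)Nc1ccc2oc(-c3ccccc3)c(O)c(=O)c2c1`) gave 36000 nM in the same test, two values within the scatter of each other. Compound 4 (`CC(=O)Nc1ccc2oc(-c3ccc(F)cc3)c(O)c(=O)c2c1`) differs from compound 3 by fluoro in place of hydrogen on an aromatic carbon, para to a large group (fluoro in place of hydrogen on an aromatic carbon). For the measured compounds named here, no measured pair shows this change, so the expectation rests on compound 3 at 36000 nM as its starting point. In this assay the expected step is a 1.1-fold higher number from compound 3 to compound 4 (0.02 log units; within the scatter) and lies within the scatter. For compound 4 the estimated value is 38000 nM and the expected range runs from 16000 nM to 90000 nM in this test.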

Compound 4, half-maximal inhibitory concentration: 26000 nM
Estimate against measurement, compound 4: 1.5-fold (0.16 log units) above, and the stated range covers the measured number.
By their numbers in this assay, from the lowest: compounds 4, 3 and 2 (each within the scatter of the next). At a limit, above all of these: compound 1.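

For the compounds shown here, the pair gives the first single-place comparison in this set: with fluoro in place of hydrogen on an aromatic carbon, para to a large group, this assay shows a 1.4-fold lower number from compound 3 to compound 4 (0.14 log units; within the scatter). At this position, then, the change does not move the reading beyond the scatter. Compound 1 stands at a limit, not a number: the limit of > 125000 nM in this assay, at which 1 of the 4 values shown sits.

From the compounds shown here alone, what a methoxy group, an amine or a carboxylic acid would do at the same place stays open. So does whether fluoro would give a similar step on another compound in this set.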